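From Two Chlorines to One: What Compound 4 May Give

The source may report more compounds than this note shows. Statements on the series, on what has been measured and on what is new or still open speak of the compounds shown alone.

Of the compounds shown here, three sharing one core have been measured in a functional assay on A549 cells (Homo sapiens) for cytotoxicity, read by sulforhodamine B assay, with a stated time of 48 h; a lower number here means a stronger inhibitor of growth, a higher number a weaker inhibitor of growth. Compound 1 `ClCc1ccccc1Cn1cnc2c(Cl)nc(Cl)nc21` gives 2230 nM. Compound 2 `ClCc1ccc(Cn2cnc3nc(Cl)nc(Cl)c32)cc1` gives 2130 nM, a number within the scatter of compound 1, so the two cannot be told apart. Compound 3 `ClCc1cccc(Cn2cnc3nc(Cl)nc(Cl)c32)c1` gives 12000 nM, a higher number that lies beyond the scatter of compound 1. Compound 1 thus stands second highest of the three numbers, side by side with compound 2 and clearly lower than compound 3.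

Compound 4 `Nc1nc(Cl)c2ncn(Cc3ccccc3CCl)c2n1` has not yet been measured. It differs from compound 1 in one place: amino in place of chloro on an aromatic carbon. Within the data shown here, no measured pair shows the effect of this change, so the expectation rests on compound 1 alone. Because compound 1 gives 2230 nM and the change involves a single heavy atom, only a modest shift toward a higher number is expected, estimated as a 1.8-fold higher number from compound 1 to compound 4 (0.25 log units; within the scatter). Compound 4 is therefore expected to give about 4000 nM, within a range from 1000 nM to 16000 nM.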

Compound 4, concentration for 50% growth inhibition: 21900 nM
Compound 4: middle estimate off by 5.5-fold (0.74 log units), on the low side, and the stated range ends below it.
By their numbers in this assay, from the lowest: compounds 2 and 1 (each within the scatter of the next); then compounds 3 and 4 (each within the scatter of the next).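

Compounds 1 to 3 all carry a chloro group on this aromatic carbon between two ring nitrogen atoms, so they could not show what happens when that group is exchanged. The exchange for amino gives the first view of this in this assay: growth inhibition becomes weaker, with a 9.8-fold higher number from compound 1 to compound 4 (0.99 log units; beyond the scatter), so this carbon is sensitive to what sits on it, even though only one heavy atom is exchanged. No measurement at hand explains why the change has this effect.

A single example cannot tell whether the weaker inhibition is specific to amino or follows any replacement of chloro here. A methoxy or methyl group at this carbon would help settle that, and the same amino change on compound 2 or compound 3 would test whether the step carries over.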